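Swapping a Halogen on the Aryl Ring: Fluoro to Bromo

A few compounds are considered here, and "the series" means these few. Any claim that something is new, unique, unknown or untested is made for them only; others in the source may bear on it.

Of the compounds shown here, two sharing one core have been tested in an assay on isolated protein for displacement of a labelled ligand from melanin-concentrating hormone receptor 1 (Homo sapiens); on this read-out lower numbers stand for stronger inhibition and higher numbers for weaker inhibition. Compound 1 `CCc1cc(N)c2cc(NC(=O)/C=C/c3ccc(C(F)(F)F)cc3)ccc2n1` carries an ethyl chain and a trifluoromethyl group on its aryl ring; in this assay compound 1 gives 1.2 nM. Compound 2 `CCCc1cc(N)c2cc(NC(=O)/C=C/c3ccc(F)cc3)ccc2n1` carries a propyl chain and a fluoro group instead, and in this assay compound 2 gives 130 nM. Of the two numbers, compound 2 shows the higher one, standing well apart from compound 1, whose number is the lower of the pair.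

Compound 3 `CCCc1cc(N)c2cc(NC(=O)/C=C/c3ccc(Br)cc3)ccc2n1` is the next compound, not yet measured. It differs from compound 2 in a single way: bromo in place of fluoro on an aromatic carbon. Among the measured compounds shown here, no measured pair shows this exact change, so no step size is available from the data. Since compound 1, with a different group at that same carbon, gives 1.2 nM, a change at that position appears able to move the number far. For the step from compound 2 to compound 3 a moderate lowering of the number is expected, a 4.3-fold lower number from compound 2 to compound 3 (0.64 log units; beyond the scatter). Compound 3 is therefore estimated to give 30 nM, within a range from 8 nM to 120 nM.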

Compound 3, half-maximal inhibitory concentration: 4 nM
Compound 3: middle estimate off by 7.5-fold (0.88 log units), on the high side, outside the stated range (below it).
By their numbers in this assay, from the lowest: compound 1; then compound 3; then compound 2.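

In this assay the exchange of 4-fluorophenyl for 4-bromophenyl gives a 33-fold lower number from compound 2 to compound 3 (1.51 log units; beyond the scatter) and, with the propyl chain and the rest of the shared core unchanged, this large step can be traced to a single place in the molecule. The earlier pair could not show this, since its two compounds differ in both the chain and the aryl group. Here one heavy atom replaces one heavy atom on a carbon para to a large group, with no hydrogen-bond donor, acceptor or net charge entering or leaving, yet that is enough to move the number well beyond the scatter, and nothing at hand accounts for the size of this step.

As far as these compounds go, whether the trend follows the halogens or is particular to bromo remains open, and a chloro or iodo group on the same carbon, or a non-halogen such as methyl or methoxy, would help to settle that. Also open, from the compounds shown here alone, is whether the same exchange of fluoro for bromo gives a step of similar size when an ethyl chain replaces the propyl chain.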